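Swapping phenyl for furan-2-yl on a long-chain amide

The source may report more compounds than this note shows. Statements on the series, on what has been measured and on what is new or still open speak of the compounds shown alone.

Compound 1 `CCCCCCCCNC(=O)[C@@H](NC(=O)c1ccco1)[C@@H](C)O`: in a functional assay on HepG2 cells (Homo sapiens) for cytotoxicity, read by MTT assay, with a stated time of 48 h (on this read-out higher numbers stand for weaker inhibition and lower numbers for stronger inhibition), compound 1 gives 192000 nM.
Compound 2 `CCCCCCCCCCCCCCNC(=O)[C@@H](NC(=O)c1ccco1)[C@@H](C)O`: in this assay compound 2 gives > 400000 nM, which is a limit of the assay.
Compound 3 `CCCCCCCCCCCCCCCCCCNC(=O)[C@@H](NC(=O)c1ccccc1)[C@@H](C)O`: in this assay compound 3 gives > 400000 nM, which is also a limit of the assay.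

Compound 3 thus stands at the limit of > 400000 nM in this assay, at which 2 of the 3 values shown sit. Compound 4 `CCCCCCCCCCCCCCCCCCNC(=O)[C@@H](NC(=O)c1ccco1)[C@@H](C)O` differs from compound 3 by furan-2-yl in place of phenyl on a carbonyl carbon. Within the data shown here, no measured step changes this ring; the only measured step, an at least 2.0-fold higher number from compound 1 to compound 2 (0.31 log units; beyond the scatter), lengthens the chain and already ends at the limit. Because that chain step reached the limit in an at least 2.0-fold higher number from compound 1 to compound 2 (0.31 log units; beyond the scatter), compound 4 is expected to show no step beyond the scatter, a step that the limit leaves unreadable from compound 3 to compound 4, and most likely another limit. Compound 4 is estimated at 500000 nM, between 250000 nM and 2000000 nM.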

Compound 4, half-maximal inhibitory concentration: 42300 nM
For compound 4 the middle estimate is 12-fold (1.07 log units) above the measured one; the measured number lies below the stated range.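

With the long chain of compound 3 held fixed, the ring on the carbonyl carbon matters: furan-2-yl in place of phenyl gives an at least 9.4-fold lower number from compound 3 to compound 4 (0.97 log units; beyond the scatter). Among the furan-2-yl amides, chain length has no single direction: an at least 2.0-fold higher number from compound 1 to compound 2 (0.31 log units; beyond the scatter), but an at least 9.4-fold lower number from compound 2 to compound 4 (0.97 log units; beyond the scatter) and a 4.5-fold lower number from compound 1 to compound 4 (0.66 log units; beyond the scatter), so compound 2 goes against any steady trend. Compound 2 and compound 3 are limits, so the steps starting from them have no exact size: the limit of > 400000 nM in this assay, at which 2 of the 4 values shown sit.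

From the compounds shown here alone, it remains open whether the ring swap gives a similar step on the shorter chain of compound 1. Going by these compounds, it is also open whether a thiophen-2-yl ring on the carbonyl carbon would behave like furan-2-yl.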